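Shifting One Hydroxyl: From Compound 2 to Compound 3

A few compounds are considered here, and "the series" means these few. Any claim that something is new, unique, unknown or untested is made for them only; others in the source may bear on it.

For the measured compounds named here, in a functional assay, with a stated time of 30 min (on this read-out higher numbers stand for weaker inhibition and lower numbers for stronger inhibition), compound 2 `Oc1ccc(O)c(/C=N/c2ccc(OCc3ccccc3)cc2)c1` gives 21300 nM, the only actual number in this small set. Compound 1 `Cc1cccc(/C=N/c2ccc(OCc3ccccc3)cc2)c1O` is reported in this assay only as a limit, > 200000 nM. Going by the values given here, the single measured step, an at least 9.3-fold lower number from compound 1 to compound 2 (0.97 log units; beyond the scatter), shows that the ring attached to the carbon double-bonded to nitrogen can move the read-out a good deal; one of its two values is a limit (the limit of > 200000 nM in this assay, at which 1 of the 2 values shown sits), so its true size is not known. Compound 3 `Oc1ccc(/C=N/c2ccc(OCc3ccccc3)cc2)c(O)c1` differs from compound 2 by 2,4-dihydroxyphenyl in place of 2,5-dihydroxyphenyl on a carbon with a double bond to nitrogen. Among the compounds with values here, no measured step compares two dihydroxyphenyl patterns with each other, so the evidence bears on this change only loosely. A step from compound 2 to compound 3 of about a 1.2-fold higher number from compound 2 to compound 3 (0.07 log units; within the scatter) is expected, within or just beyond the scatter in either direction. Compound 3 is therefore estimated at 25000 nM in this assay, with a range from 7000 nM to 90000 nM.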

Compound 3, half-maximal inhibitory concentration: > 200000 nM
Compound 3 gave a limit, no number; the forecaster's own chance of this, stated with the estimate: 15%; middle value at least 8.0-fold (0.90 log units) from the limit.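

Moving one hydroxyl while keeping the same atoms is enough to change the result in this assay, with an at least 9.3-fold higher number from compound 2 to compound 3 (0.97 log units; beyond the scatter). On these data alone, the value for compound 3, > 200000 nM, is a limit and not a number, so the true size of this step is unknown. The earlier pair had changed the ring's groups as well, whereas this pair isolates the hydroxyl pattern, and among the compounds shown only 2,5-dihydroxyphenyl gives an actual number, with the other two at the same ceiling: the limit of > 200000 nM in this assay, at which 2 of the 3 values shown sit.

The step from compound 1 to compound 3 cannot be read, as both values are limits. As far as these compounds go, it remains open which hydroxyl of the 2,5-dihydroxyphenyl ring matters more, and whether an amine or a carboxylic acid could stand in place of either one.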